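The source may hold more compounds than are shown below. What is called first, only, known or untested is meant among the compounds shown, and "the series" means these compounds.

Compounds measured in a functional assay on CLL cells (Homo sapiens) for cytotoxicity, read by MTT assay, with a stated time of 48 h; on this read-out lower numbers stand for an effect already at smaller amounts and higher numbers for an effect only at larger amounts of compound: compound 1 `C=C(CC)C(=O)c1ccc(OCC(=O)NCCO)c(Cl)c1Cl`, compound 2 `C=C(CC)C(=O)c1ccc(OCC(=O)NCO[N+](=O)[O-])c(Cl)c1Cl`, compound 3 `C=C(CC)C(=O)c1ccc(OCC(=O)Nc2ccc(O)c(Cl)c2)c(Cl)c1Cl`.

Compound 1 gives > 25000 nM, which is a limit of the assay and not a number; this is the limit of > 25000 nM in this assay, at which 1 of the 3 values shown sits. Compound 2 gives 4100 nM and compound 3 gives 5500 nM. Of the two numbers shown, compound 3 gives the higher one, though a 1.3-fold higher number from compound 2 to compound 3 (0.13 log units; within the scatter), so the two stand together. Compound 4 `C=C(CC)C(=O)c1ccc(OCC(=O)NO)c(Cl)c1Cl` differs from compound 3 in one place: hydroxy in place of 3-chloro-4-hydroxyphenyl on an amide-type nitrogen. The step that bears on this runs the other way, from a 2-hydroxyethyl to the same aryl group: an at least 4.5-fold lower number from compound 1 to compound 3 (0.65 log units; beyond the scatter). Taking the aryl group away again is therefore expected to give a higher number, and compound 4 is estimated at 15000 nM (range 5000 nM to 40000 nM), with a fair chance that only a limit is reported. That expectation amounts to a 2.7-fold higher number from compound 3 to compound 4 (0.44 log units; beyond the scatter).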

Compound 4, half-maximal effective concentration: 4500 nM
Estimate against measurement, compound 4: 3.3-fold (0.52 log units) above, and the stated range ends above it.
By their numbers in this assay, from the lowest: compounds 2, 4 and 3 (each within the scatter of the next). At a limit, above all of these: compound 1.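

On the amide-type nitrogen the aromatic ring proves dispensable: hydroxy in place of 3-chloro-4-hydroxyphenyl gives a 1.2-fold lower number from compound 3 to compound 4 (0.09 log units; within the scatter), and hydroxy in place of (nitrooxy)methyl gives a 1.1-fold higher number from compound 2 to compound 4 (0.04 log units; within the scatter). Hydroxy in place of 2-hydroxyethyl gives an at least 5.5-fold lower number from compound 1 to compound 4 (0.74 log units; beyond the scatter), a step read against a limit of the assay in compound 1. Three very different groups on this nitrogen thus stand together, and only the 2-hydroxyethyl of compound 1 stands apart. Going by these compounds, whether an amine, a carboxylic acid or a longer chain ending in hydroxy on this nitrogen would join those three or stay with compound 1 remains open.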